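Adding a methoxy to the core of a cinnamamide trimethoxybenzophenone

This account rests on a few compounds, and the source may have more. Where it says the series, first, only, none or still open, it means among the compounds named here.

The measured compounds:
compound 1, `COc1cccc(/C=C/C(=O)Nc2cc(C(=O)c3cc(OC)c(OC)c(OC)c3)ccc2OC)c1`, 1900 nM
compound 2, `COc1ccc(C(=O)c2cc(OC)c(OC)c(OC)c2)cc1NC(=O)/C=C/c1ccc(F)c(F)c1`, 4200 nM

Both numbers come from a functional assay on HT-29 cells (Homo sapiens) for cytotoxicity, read by MTT assay, with a stated time of 72 h; a lower number here means a stronger inhibitor, a higher number a weaker inhibitor. For the measured compounds named here, compound 1 stands at the lower of the two numbers, so it is the stronger inhibitor of the pair; compound 2 is the nearer and only neighbour, and the one step between them, a 2.2-fold higher number from compound 1 to compound 2 (0.34 log units; beyond the scatter), comes from swapping the ring at the far end of the double-bonded chain.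

The new compound 3, `COc1cccc(/C=C/C(=O)Nc2cc(C(=O)c3cc(OC)c(OC)c(OC)c3)cc(OC)c2OC)c1`, is compound 1 with one change: methoxy in place of hydrogen on an aromatic carbon. This change touches the core carrying the amide nitrogen, not the chain-end ring that the step from compound 1 to compound 2 altered, so that step does not bear on it directly. Nothing measured here reports on a methoxy added at this place of the core. Going by the values given here, with no step to lean on, the expectation is that compound 3 will sit close to compound 1, with a step of a 1.1-fold higher number from compound 1 to compound 3 (0.02 log units; within the scatter) in this assay, which is within the scatter. Compound 3 is therefore estimated at 2000 nM, with a range from 700 nM to 6000 nM.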

Compound 3, half-maximal inhibitory concentration: 8700 nM
Estimate against measurement, compound 3: 4.4-fold (0.64 log units) below; the measured number lies above the stated range.
By their numbers in this assay, from the lowest: compound 1; then compound 2; then compound 3.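

In this assay, the aromatic carbon of the core that is ortho to a methoxy group and meta to two large groups does not take an added methoxy without a cost, giving a 4.6-fold higher number from compound 1 to compound 3 (0.66 log units; beyond the scatter). For the compounds shown here, the earlier compounds differ only at the far end of the chain, so this is the first sign that the number also responds to a change on the core, and that a group of just 2 heavy atoms in place of a hydrogen is enough to move it beyond the scatter. Why the number rises cannot be said, as no measurement at hand speaks to the cause.

Going by these compounds, it remains open whether this rise belongs to methoxy itself or would follow any group at this carbon, a question that a fluorine, a hydroxyl or an amine in the same place could help to settle. On these data alone, it is also open whether the same added methoxy would shift the number in a similar way on compound 2, whose chain ends in 3,4-difluorophenyl rather than 3-methoxyphenyl.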